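Swapping the amide aryl group on the shared core

The compounds below may be only part of what the source reports. "The series", "measured", "known", "first", "only" and "open" are said of these compounds alone.

Measured so far in a functional assay on A549 cells (Homo sapiens) for antiproliferative activity, read by CCK-8 assay, with a stated time of 72 h; a lower number here means a stronger inhibitor, a higher number a weaker inhibitor:
compound 1 `COc1cccc(C(=O)Nc2cccc(-c3oc4cc(-c5ccc(F)cc5)ccc4c(=O)c3O)c2)c1` gives 10800 nM
compound 2 `Cc1cc(C)cc(C(=O)Nc2cccc(-c3oc4cc(-c5ccc(F)cc5)ccc4c(=O)c3O)c2)c1` gives 3740 nM
compound 3 `O=C(Nc1cccc(-c2oc3cc(-c4ccc(F)cc4)ccc3c(=O)c2O)c1)c1ccc([N+](=O)[O-])cc1` gives 2440 nM

Compound 1 stands at the highest number of the three, meaning it is the weakest inhibitor in this set. Compound 4 `CCCc1ccc(C(=O)Nc2cccc(-c3oc4cc(-c5ccc(F)cc5)ccc4c(=O)c3O)c2)cc1` differs from it in one place: 4-propylphenyl in place of 3-methoxyphenyl on a carbonyl carbon. Among the measured compounds shown here, two measured steps bear on this, since both also exchange the aryl group on the same carbonyl carbon: a 2.9-fold lower number from compound 1 to compound 2 (0.46 log units; beyond the scatter) and a 4.4-fold lower number from compound 1 to compound 3 (0.65 log units; beyond the scatter). Both moves away from the 3-methoxyphenyl gave a lower number beyond the scatter, so a similar modest drop is expected here, a 3.1-fold lower number from compound 1 to compound 4 (0.49 log units; beyond the scatter). Compound 4 is therefore estimated at 3500 nM, within a range of 1500 nM to 9000 nM.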

Compound 4, half-maximal inhibitory concentration: 47600 nM
Beside the measured number, compound 4's estimate is 14-fold (1.13 log units) below it, outside the stated range (above it).
By their numbers in this assay, from the lowest: compounds 3 and 2 (each within the scatter of the next); then compound 1; then compound 4.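

Leaving the 3-methoxyphenyl on this carbonyl carbon does not always lower the number: 4-propylphenyl gives a 4.4-fold higher number from compound 1 to compound 4 (0.64 log units; beyond the scatter), against the drops seen with compound 2 and compound 3. The steps of a 20-fold higher number from compound 3 to compound 4 (1.29 log units; beyond the scatter) and a 13-fold higher number from compound 2 to compound 4 (1.10 log units; beyond the scatter) are large, so the choice of aryl group here can move the number a long way. Nothing available explains this rise. Still open, from the compounds shown here alone, is whether the loss follows the propyl chain itself: an ethyl group, an amine or a carboxylic acid on that same aromatic carbon would test this.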